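Swapping dimethylamino for methoxy on a growth inhibitor

The source may hold more compounds than are shown below. What is called first, only, known or untested is meant among the compounds shown, and "the series" means these compounds.

Measured so far:
- Compound 1 `CN(C)c1ccc(NS(=O)(=O)c2c(F)c(F)c(F)c(F)c2F)cc1`: 27 nM
- Compound 2 `Cc1ccc(NS(=O)(=O)c2c(F)c(F)c(F)c(F)c2F)cc1C`: 37 nM
- Compound 3 `O=S(=O)(Nc1ccc2c(c1)OCCO2)c1c(F)c(F)c(F)c(F)c1F`: 140 nM

These numbers come from a functional assay on P388 cells (Mus musculus) for inhibition; a higher number here means a weaker inhibitor of growth, a lower number a stronger inhibitor of growth. The values of compound 1 and compound 2 lie within the scatter of each other, so they count as alike, and together they sit at the low end of the three. Compound 3 stands apart at 140 nM, higher than compound 1 by more than the scatter.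

The next compound is compound 4 `COc1ccc(NS(=O)(=O)c2c(F)c(F)c(F)c(F)c2F)cc1`. It keeps the core of compound 1 and changes one group: methoxy in place of dimethylamino on an aromatic carbon. In words, this is methoxy in place of dimethylamino on an aromatic carbon, para to a large group.

Among the compounds with values here, no two measured compounds differ in one place only, so nothing here measures this swap directly. Compound 2, at 37 nM, shows that a compound without dimethylamino can stay close to compound 1. Compound 3, at 140 nM, shows that such a compound can also land clearly higher. A modest rise in the number therefore seems most likely. The expected move is a 2.0-fold higher number from compound 1 to compound 4 (0.31 log units; beyond the scatter). For compound 4 the estimated value is 55 nM, with an expected range from 22 nM to 140 nM.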

Compound 4, concentration for 50% growth inhibition: 12 nM
Compound 4: the middle estimate sits 4.6-fold (0.66 log units) above what was measured; measured number outside the range, below it.
By their numbers in this assay, from the lowest: compound 4; then compounds 1 and 2 (each within the scatter of the next); then compound 3.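

In this assay, within the data shown here, replacing dimethylamino with methoxy on an aromatic carbon, para to a large group, gives a 2.3-fold lower number from compound 1 to compound 4 (0.35 log units; beyond the scatter), the first direct reading of a single change in this set. It shows that dimethylamino is not required at this position for growth inhibition: methoxy, with one heavy atom fewer and the same counts of hydrogen-bond donors and acceptors, gives a lower number on the same core, so this place accepts a change of group without a loss in this assay. Nothing available here explains why the methoxy compound gives the lower number.

A single step cannot show which feature of the swap matters, and a hydroxy group, an ethoxy group or a plain hydrogen at the same place would help to separate the effect of the oxygen from that of the group's size. Going by these compounds, it also remains open whether methoxy would give a similar step on a different aromatic carbon, or with a second group added to the same ring.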